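Switching the aryl sulfonyl group in an EP3 antagonist series

The source may hold more compounds than are shown below. What is called first, only, known or untested is meant among the compounds shown, and "the series" means these compounds.

Two measured compounds share one core and differ mainly in the groups at either end. Compound 1 `O=C(NC/C=C1\CCCc2cnn(Cc3ccc(Cl)cc3Cl)c21)NS(=O)(=O)c1ccc(Cl)cc1` is tested in a functional assay on CHO-K1 cells for antagonist activity at prostaglandin E2 receptor EP3 subtype (Homo sapiens), read by TR-FRET and cAMP accumulation, with a stated time of 30 min (on this read-out higher numbers stand for weaker inhibition and lower numbers for stronger inhibition), and gives 12 nM. Compound 2 `O=C(NC/C=C1\CCCc2cnn(C3CCN(c4ccc(F)cc4)CC3)c21)NS(=O)(=O)c1cc(Cl)c(Cl)s1` gives 6 nM in this assay. Compound 1 carries the higher of the two numbers, but the two values lie within the scatter of one another, so no order between compound 1 and compound 2 can be drawn.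

The unmeasured compound 3 `COc1ccccc1S(=O)(=O)NC(=O)NC/C=C1\CCCc2cnn(Cc3ccc(Cl)cc3Cl)c21` keeps everything of compound 1 except the ring on the sulfonyl sulfur: 2-methoxyphenyl in place of 4-chlorophenyl on a sulfonyl sulfur. Among the compounds with values here, no measured pair in this set isolates a change of that kind, so there is no measured step to lean on. The author expects the step of a 2.5-fold higher number from compound 1 to compound 3 (0.40 log units; beyond the scatter) in this assay to be a moderate rise, with a real chance that it stays inside the scatter. On that basis compound 3 is estimated at 30 nM, in a range from 8 nM to 120 nM.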

Compound 3, half-maximal inhibitory concentration: 114 nM
Compound 3: middle estimate off by 3.8-fold (0.58 log units), on the low side, within the range that was stated.
By their numbers in this assay, from the lowest: compounds 2 and 1 (each within the scatter of the next); then compound 3.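

In this assay, the group on the sulfonyl sulfur proves to be a place where a single change registers clearly: with the rest of compound 1 kept, 2-methoxyphenyl in place of 4-chlorophenyl brings a 9.5-fold higher number from compound 1 to compound 3 (0.98 log units; beyond the scatter). The earlier pair could not show this, as compound 1 and compound 2 differ at both ends of the shared core and their values lie within the scatter of each other, so neither end could be judged alone. No measurement available here accounts for the size of this rise.

This one pair leaves open whether the rise goes with losing the chlorine or with gaining the methoxy group, and a plain phenyl or a methyl on the sulfonyl sulfur would help to separate the two. It also leaves open whether 2-methoxyphenyl would bring a similar rise in the setting of compound 2, which carries a different group at the other end of the shared core.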